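This account rests on a few compounds, and the source may have more. Where it says the series, first, only, none or still open, it means among the compounds named here.

Measured compounds in a functional assay on MOLT-4 cells (Homo sapiens) for antiproliferative activity, read by MTT assay, with a stated time of 72 h; on this read-out higher numbers stand for weaker inhibition and lower numbers for stronger inhibition:
- compound 1, `O=C1NC(=S)S/C1=C\C1=Cc2cc(Br)ccc2OC1`, gives 38200 nM
- compound 3, `CC1Oc2ccc(Br)cc2C=C1/C=C1\SC(=S)NC1=O`, gives 20500 nM
- compound 2, `O=C(O)CN1C(=O)/C(=C/C2=Cc3cc(Br)ccc3OC2)SC1=S`, gives only a limit of the assay, > 25000 nM

Compound 3 holds the lowest of the two readable numbers in this assay, with compound 1 nearest; the step of a 1.9-fold lower number from compound 1 to compound 3 (0.27 log units; within the scatter) is within the scatter, so the two cannot be ranked, and compound 2 contributes no number, only a limit.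

The next compound, compound 4, `CC1Oc2ccc(Br)cc2C=C1/C=C1\SC(=S)N(CC(=O)O)C1=O`, is built from compound 3 by the change (carboxymethyl in place of hydrogen on an amide-type nitrogen in a ring). Among the measured compounds shown here, the one measured step of the same kind is a step that the limit leaves unreadable from compound 1 to compound 2, which the limit of > 25000 nM in this assay, at which 1 of the 3 values shown sits, leaves without a readable size or direction. For the measured compounds named here, there is thus no step that tells what this change does to the number in this assay, beyond the fact that the one analogue carrying carboxymethyl on this nitrogen reported only a limit.

Compound 4 is therefore expected to land near the upper edge of the measurable range, with a substantial chance that this assay again returns only a limit. The step of a 1.5-fold higher number from compound 3 to compound 4 (0.17 log units; within the scatter) is expected to be small or not readable rather than a clear gain. The estimate for compound 4 is 30000 nM, within 12000 nM to 80000 nM.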

Compound 4, half-maximal inhibitory concentration: > 50000 nM
Compound 4: a limit, no number (the forecaster's own chance of this, stated with the estimate: 55%); middle value at least 1.6-fold (0.22 log units) away from the limit.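

Working note on the amide-type nitrogen of the five-membered ring: in this assay, carboxymethyl in place of hydrogen now has a readable direction, with an at least 2.4-fold higher number from compound 3 to compound 4 (0.38 log units; beyond the scatter) as the one step that shows it. Compound 4 gives > 50000 nM, which is a limit and not a number, so this step has a floor but no measured size. Among the compounds shown here, the steps from compound 1 to compound 2 and from compound 2 to compound 4 cannot be read, so the direction rests on the single pair of compound 3 and compound 4, and the effect of the ring methyl in the presence of carboxymethyl stays unknown.

The compounds shown do not tell whether the higher number belongs to the carboxylic acid of the carboxymethyl group or to any group on this nitrogen. A methyl ester of that acid, a plain methyl or a longer chain ending in a carboxylic acid, each on the core of compound 3, would begin to separate these readings, provided the result falls within the measurable range of this assay rather than at a limit.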